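The compounds below may be only part of what the source reports. "The series", "measured", "known", "first", "only" and "open" are said of these compounds alone.

Compound 1 `CCNC(=O)/C=C/C=C/[C@H](O)Cc1ccc(OC)c(OC)c1` is one of two compounds that have been tested for their power to slow the growth of a human nerve-tumour cell line. In a functional assay on IMR-32 cells (Homo sapiens) for antiproliferative activity, read by sulforhodamine B assay, with a stated time of 48 h (a lower number here means a stronger inhibitor, a higher number a weaker inhibitor), compound 1 gives 9430 nM. Compound 2 `COc1ccc(C[C@@H](O)/C=C/C=C/C(=O)N2CCCCC2)cc1OC` gives 11000 nM in this assay. The step of a 1.2-fold higher number from compound 1 to compound 2 (0.07 log units; within the scatter) shows that exchanging the group on the amide nitrogen left the number essentially where it was, so compound 1 and compound 2 sit within the scatter of each other and neither can be called the stronger.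

Compound 3 `COc1ccc(CNC(=O)/C=C/C=C/[C@H](O)Cc2ccc(OC)c(OC)c2)cc1` differs from compound 1 in one place: 4-methoxyphenyl in place of methyl on a saturated chain carbon bound to an amide-type nitrogen. Among the compounds with values here, the only measured step that bears on this change is the step from compound 1 to compound 2, which also altered the amide nitrogen's substituent and stayed within the scatter. On that basis no step beyond the scatter is expected in this assay, and compound 3 is estimated at 7500 nM, between 2500 nM and 22000 nM, which means an expected step of a 1.3-fold lower number from compound 1 to compound 3 (0.10 log units; within the scatter).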

Compound 3, half-maximal inhibitory concentration: 17400 nM
Estimate against measurement, compound 3: 2.3-fold (0.37 log units) below; the range from low to high includes it.
By their numbers in this assay, from the lowest: compounds 1, 2 and 3 (each within the scatter of the next).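

Putting 4-methoxyphenyl in place of methyl on a saturated chain carbon bound to an amide-type nitrogen gives a 1.8-fold higher number from compound 1 to compound 3 (0.27 log units; within the scatter) in this assay. The earlier step had replaced ethylamino with piperidin-1-yl, whereas this one shows that a six-membered aromatic ring carrying a methoxy group, reached through this carbon, also leaves the number within the scatter, even though eight heavy atoms enter where one leaves. No measurement at hand gives a reason for this outcome.

From the compounds shown here alone, it remains open whether an amine or a carboxylic acid in place of methyl at this carbon would shift the number beyond the scatter. The same question stands for a longer chain between the amide nitrogen and the aromatic ring.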